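This account rests on a few compounds, and the source may have more. Where it says the series, first, only, none or still open, it means among the compounds named here.

Compound 1 `CC[C@H](C)[C@H](N)CN(C(=O)[C@@H]1C[C@H]1c1ccc(Cl)cc1)c1ccc(-c2ccccc2)cc1`: in a functional assay for agonist activity at G protein-coupled receptor 88 (Homo sapiens), read by HTRF and cAMP accumulation (a higher number here means that more compound is needed for the effect, a lower number that less compound is needed), compound 1 gives 4300 nM.
Compound 2 `CC[C@H](C)[C@H](N)CN(C(=O)[C@@H]1C[C@H]1c1cccc(OC)c1)c1ccc(-c2ccccc2)cc1`: in this assay compound 2 gives 3000 nM.
Compound 3 `CC[C@H](C)[C@H](N)CN(C(=O)[C@@H]1C[C@H]1c1cc(F)ccc1F)c1ccc(-c2ccccc2)cc1`: in this assay compound 3 gives 770 nM.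

Compound 3 has the lowest of these three numbers, so it needs the least compound for the effect; the step of a 3.9-fold lower number from compound 2 to compound 3 (0.59 log units; beyond the scatter) and the step of a 5.6-fold lower number from compound 1 to compound 3 (0.75 log units; beyond the scatter) both lie beyond the scatter, while a 1.4-fold lower number from compound 1 to compound 2 (0.16 log units; within the scatter) does not. All three compounds share one core and differ only in the aromatic group on a saturated ring carbon. Compound 4 `CC[C@H](C)[C@H](N)CN(C(=O)[C@@H]1C[C@H]1c1cccnc1)c1ccc(-c2ccccc2)cc1` is the next member of this series; the change is pyridin-3-yl in place of 2,5-difluorophenyl on a saturated ring carbon. The three measured steps each swap one aromatic group for another at the same position, so all of them bear on this change: two are modest, one is within the scatter. Among the compounds with values here, none of them brings in a ring with a hetero atom, so the direction is uncertain; the one guide is that removing the 2,5-difluorophenyl group undoes the change that produced the step of a 5.6-fold lower number from compound 1 to compound 3 (0.75 log units; beyond the scatter). In this assay compound 4 is therefore expected to give a higher number than compound 3, a step of roughly a 3.9-fold higher number from compound 3 to compound 4 (0.59 log units; beyond the scatter). The estimate for compound 4 is 3000 nM, with a range from 900 nM to 10000 nM.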

Compound 4, half-maximal effective concentration: 1500 nM
The estimate for compound 4 lay 2.0-fold (0.30 log units) above the measured number; the range from low to high includes it.
By their numbers in this assay, from the lowest: compounds 3, 4, 2 and 1 (each within the scatter of the next, the first and the last beyond it).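

Pyridin-3-yl is the first ring with a hetero atom at this saturated ring carbon, and in this assay it cannot be told apart from 2,5-difluorophenyl (a 1.9-fold higher number from compound 3 to compound 4 (0.29 log units; within the scatter)) or from 3-methoxyphenyl (a 2.0-fold lower number from compound 2 to compound 4 (0.30 log units; within the scatter)). Against 4-chlorophenyl the step is clear (a 2.9-fold lower number from compound 1 to compound 4 (0.46 log units; beyond the scatter)), so the two fluorines of compound 3 are not the only route to a step beyond the scatter from compound 1, although the 3-methoxyphenyl of compound 2 does not give such a step. Nothing measured here accounts for these steps.

The compounds shown leave open whether the place of the ring nitrogen matters, as pyridin-2-yl or pyridin-4-yl would test. They also leave open whether a saturated ring holding an amine, such as piperidin-4-yl, would be accepted at this carbon.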